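Compound 3: removing the chloro from a limit compound

The compounds below may be only part of what the source reports. "The series", "measured", "known", "first", "only" and "open" are said of these compounds alone.

In a functional assay on HL-60 cells (Homo sapiens) for antiproliferative activity (a higher number here means a weaker inhibitor of growth, a lower number a stronger inhibitor of growth), compound 1 (`COc1cc(-n2cc(-c3ccc(Cl)cc3)[nH]c2=O)cc(OC)c1OC`) gives > 100000 nM as a limit, not a number. Compound 2 (`COc1ccc(-n2cc(-c3ccc(OC)c(OC)c3)[nH]c2=S)cc1Cl`) gives > 100000 nM as a limit too. Going by the values given here, no measured step is available. Compound 3 (`COc1cc(-n2cc(-c3ccccc3)[nH]c2=O)cc(OC)c1OC`) differs from compound 1 by hydrogen in place of chloro on an aromatic carbon in the form of hydrogen in place of chloro on an aromatic carbon, para to a large group. The expected step of a number no higher from compound 1 to compound 3 (the limit leaves the size open) in this assay stays within the scatter, with no firm direction, an expectation resting only on compound 1 and compound 2 sharing the limit of > 100000 nM in this assay, at which 2 of the 2 values shown sit, as their position. Compound 3 is estimated at 100000 nM with an expected range from 30000 nM to 200000 nM and may well report only a limit.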

Compound 3, concentration for 50% growth inhibition: 63100 nM
Estimate against measurement, compound 3: 1.6-fold (0.20 log units) above; low and high end bracket the measured number.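

In this assay compound 3 gives 63100 nM as the only true number among the compounds shown. Replacing the chloro with hydrogen para to a large group gives an at least 1.5-fold lower number from compound 1 to compound 3 (0.19 log units; that floor lies within the scatter) and so reads only as a floor, which leaves the full size of the 4-chlorophenyl to phenyl change unknown. Compound 1 and compound 2 each stay at a limit, not a number: the limit of > 100000 nM in this assay, at which 2 of the 3 values shown sit.

Still open, going by these compounds, is whether an amine or a carboxylic acid at that same ring carbon would shift the number from compound 3. On these data alone, the effect of a longer chain there also remains open.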